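Trimming the sulfonyl side chain of compound 2

This account rests on a few compounds, and the source may have more. Where it says the series, first, only, none or still open, it means among the compounds named here.

In a physicochemical assay for solubility, in phosphate buffer, measured as kinetic solubility, with a stated time of 1 h, at pH 7.4 (on this read-out higher numbers stand for higher solubility and lower numbers for lower solubility), compound 1 (`CNCC(=O)Nc1ccc(-c2nc(CS(C)(=O)=O)cc([C@@]34CCOC[C@@H]3C4)n2)cc1`) gives 167 ug/mL and compound 2 (`CCNC(=O)Nc1ccc(-c2nc(C(C)(C)S(C)(=O)=O)cc([C@@]34CCOC[C@@H]3C4)n2)cc1`) gives 78 ug/mL, the lower of the two numbers, by a gap beyond the usual scatter. Compound 3 (`CCNC(=O)Nc1ccc(-c2nc(CS(C)(=O)=O)cc([C@@]34CCOC[C@@H]3C4)n2)cc1`) differs from compound 2 in one place, with (methylsulfonyl)methyl in place of 1-methyl-1-(methylsulfonyl)ethyl on an aromatic carbon. Among the compounds with values here, no measured pair isolates this change, but compound 1, at 167 ug/mL, carries the same (methylsulfonyl)methyl while differing elsewhere. A small rise in this assay is therefore expected, a 1.4-fold higher number from compound 2 to compound 3 (0.15 log units; within the scatter), and it may stay within the scatter. Compound 3 is estimated at 110 ug/mL, with an expected range of 50 ug/mL to 220 ug/mL.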

Compound 3, solubility: 77 ug/mL
The estimate for compound 3 lay 1.4-fold (0.15 log units) above the measured number; low and high end bracket the measured number.
By their numbers in this assay, from the lowest: compounds 3 and 2 (each within the scatter of the next); then compound 1.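

In this assay, (methylsulfonyl)methyl in place of 1-methyl-1-(methylsulfonyl)ethyl on this aromatic carbon gives a 1.0-fold lower number from compound 2 to compound 3 (0.01 log units; within the scatter) and stays within the scatter, so this trimming leaves the read-out unmoved. Ethylamino in place of (methylamino)methyl on a carbonyl carbon gives a 2.2-fold lower number from compound 1 to compound 3 (0.34 log units; beyond the scatter) and lies beyond the scatter, so of these two single changes only this one registers. Going by these compounds, whether an amine or a carboxylic acid on the same aromatic carbon would shift the read-out stays open. The data shown offer no measurement that explains either step.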